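The source may report more compounds than this note shows. Statements on the series, on what has been measured and on what is new or still open speak of the compounds shown alone.

Measured compounds in a functional assay on HCC1806 cells (Homo sapiens) for inhibition, read by sulforhodamine B assay, tested at 10 uM; a lower number here means less inhibition, a higher number more inhibition at the concentration tested (going by the name of the read-out):
compound 1 `CN(C)c1ccc(C2CC(c3ccc(-n4cncn4)cc3)=NN2)cc1`, 6.8%
compound 2 `COC(=O)CC(=O)N1N=C(c2ccc(N3CCN(C)CC3)cc2)CC1c1ccc(N(C)C)cc1`, -8.3%
compound 3 `CN1CCN(c2ccc(C3=NN(C(=O)c4ccc(C(F)(F)F)cc4)C(c4ccc(N(C)C)cc4)C3)cc2)CC1`, 84.1%

Compound 3 stands highest of the three numbers in this assay; the nearest is compound 1, whose value lies well below it, beyond the scatter, and the furthest is compound 2, also beyond the scatter. Compound 4 `CN1CCN(c2ccc(C3=NN(S(=O)(=O)c4ccc(F)cc4)C(c4ccc(N(C)C)cc4)C3)cc2)CC1` is not yet measured. It differs from compound 3 in one place: (4-fluorophenyl)sulfonyl in place of (4-(trifluoromethyl)phenyl)carbonyl on an amine nitrogen in a ring.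

For the measured compounds named here, only one measured step touches the same position, the one with a number 92.4 percentage points higher from compound 2 to compound 3 (beyond the scatter), where 4-(trifluoromethyl)phenyl in place of (methoxycarbonyl)methyl on a carbonyl carbon produced that large rise. Going by the values given here, that step shows the group on the amine nitrogen in the ring governs most of the read-out, but it compares two carbonyl groups; no measured pair exchanges a carbonyl for a sulfonyl, so the direction of the present step has no anchor. An aromatic ring is kept in compound 4, which argues against a fall to the level of compound 2. A downward step of moderate size, inside a wide band, is therefore expected in this assay, a number 34.1 percentage points lower from compound 3 to compound 4 (beyond the scatter). Compound 4 is estimated at 50%, range 10% to 85%.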

Compound 4, a percentage reported as inhibition, at one concentration (the size of the read-out at that concentration, not a potency): 92.3%
Estimate against measurement, compound 4: 42.3 percentage points below; measured number above the stated range.
By their numbers in this assay, from the lowest: compound 2; then compound 1; then compounds 3 and 4 (each within the scatter of the next).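

In this assay, the exchange of (4-(trifluoromethyl)phenyl)carbonyl for (4-fluorophenyl)sulfonyl on the amine nitrogen in a ring does not separate the two compounds (a number 8.2 percentage points higher from compound 3 to compound 4 (within the scatter)), so at this position a sulfonyl carrying an aromatic ring reads the same as a carbonyl carrying one. The large rise from ((methoxycarbonyl)methyl)carbonyl now appears with both groups, once as a number 92.4 percentage points higher from compound 2 to compound 3 (beyond the scatter) and again as a number 100.6 percentage points higher from compound 2 to compound 4 (beyond the scatter), which means that among compounds 2, 3 and 4 the high read-out does not depend on the carbonyl being kept. No evidence on mechanism or properties accompanies these numbers, so the pattern remains descriptive.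

The step from compound 3 to compound 4 changes the linking unit and the substituent on the aromatic ring together, so a (4-fluorophenyl)carbonyl or a (4-(trifluoromethyl)phenyl)sulfonyl group would be needed to take the two apart. Also open, as far as these compounds go, is whether the aromatic ring is needed on the sulfonyl at all, which a methylsulfonyl group would test, and a single-concentration read-out this high gives no ranking of potency between the two compounds.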